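Swapping a dihydroxypropyl side chain for an oxiranylmethyl pyrrolidine

A few compounds are considered here, and "the series" means these few. Any claim that something is new, unique, unknown or untested is made for them only; others in the source may bear on it.

Compound 1 `Nc1ncnc2c1c(-c1ccc(Oc3ccccc3)cc1)cn2C[C@H]1CCCN1C[C@@H](O)CO`: 13500 nM
Compound 2 `CC(C)(C)c1ccc(Oc2ccc(-c3cn([C@H]4CCN(C[C@@H]5CO5)C4)c4ncnc(N)c34)cc2)cc1`: 11200 nM

In a functional assay on Ramos cells (Homo sapiens) for antiproliferative activity (a lower number here means a stronger inhibitor, a higher number a weaker inhibitor), compound 1 gives 13500 nM and compound 2 gives 11200 nM. Within the data shown here, these two numbers lie within the usual scatter of each other, so compound 1 cannot be separated from the only other measured compound.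

Compound 3 `Nc1ncnc2c1c(-c1ccc(Oc3ccccc3)cc1)cn2[C@H]1CCN(C[C@H]2CO2)C1` keeps the core of compound 1. On an aromatic nitrogen it carries 1-((oxiran-2-yl)methyl)pyrrolidin-3-yl in place of (1-(2,3-dihydroxypropyl)pyrrolidin-2-yl)methyl (1-((oxiran-2-yl)methyl)pyrrolidin-3-yl in place of (1-(2,3-dihydroxypropyl)pyrrolidin-2-yl)methyl on an aromatic nitrogen). Among the measured compounds shown here, no measured pair shows a step of this kind. The entering group is also found on compound 2, which gives 11200 nM, so no step beyond the scatter is expected in this assay. The estimated step is a 1.5-fold lower number from compound 1 to compound 3 (0.18 log units; within the scatter). With so few data the expected range is wide. For compound 3 the estimated value is 9000 nM, expected to fall between 3000 nM and 25000 nM.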

Compound 3, half-maximal inhibitory concentration: > 50000 nM
Compound 3 was reported as a limit; the forecaster's own chance of this, stated with the estimate: 15%; middle value at least 5.5-fold (0.74 log units) from the limit.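

In this assay, this first readable step at the aromatic nitrogen lies beyond the scatter: putting 1-((oxiran-2-yl)methyl)pyrrolidin-3-yl in place of (1-(2,3-dihydroxypropyl)pyrrolidin-2-yl)methyl gives an at least 3.7-fold higher number from compound 1 to compound 3 (0.56 log units; beyond the scatter). The value of compound 3 is a limit, > 50000 nM, and the step rests on it: the limit of > 50000 nM in this assay, at which 1 of the 3 values shown sits. The earlier values, which lie within the scatter of each other, gave no sign that this exchange on the shared core could cost activity.

The exchange alters the attachment to the pyrrolidine and the group on it together, and the compounds shown do not separate the two. Also open, on these data alone, is how a 1-methylpyrrolidin-3-yl group on that aromatic nitrogen would read in this assay.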